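Capping the Phenolic Hydroxy of a Chalcone Topoisomerase Inhibitor

The source may hold more compounds than are shown below. What is called first, only, known or untested is meant among the compounds shown, and "the series" means these compounds.

Compound 1 `O=C(/C=C/c1ccc(F)cc1)c1ccc(O)cc1O`: 80.2%
Compound 2 `O=C(/C=C/c1ccc(N2CCCC2)cc1)c1ccc(O)cc1O`: 87.1%
Compound 3 `O=C(/C=C/c1ccc(F)cc1)c1ccc(O)cc1`: 50.9%

In an assay on isolated protein for inhibition of DNA topoisomerase 1 (Homo sapiens), tested at 100 uM (on this read-out higher numbers stand for a stronger effect at the one concentration tested and lower numbers for a weaker effect), compound 1 stands second highest of the three, with compound 2 nearest a number 6.9 percentage points higher from compound 1 to compound 2 (within the scatter) and compound 3 furthest a number 29.3 percentage points lower from compound 1 to compound 3 (beyond the scatter). Compound 4 `COc1ccc(C(=O)/C=C/c2ccc(F)cc2)c(O)c1` differs from compound 1 by methyl in place of hydrogen on an oxygen on an aromatic ring. Among the compounds with values here, the step that bears on this is the one from compound 1 to compound 3, where the same hydroxy is removed outright and the inhibition falls a number 29.3 percentage points lower from compound 1 to compound 3 (beyond the scatter); the step to compound 2 touches a different ring. Since compound 4 alters that same hydroxy, a downward step is expected in this assay, though likely smaller than full removal: a number 18.2 percentage points lower from compound 1 to compound 4 (beyond the scatter). Compound 4 is therefore estimated at 62%, in the range 45% to 80%.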

Compound 4, a percentage reported as inhibition, at one concentration (the size of the read-out at that concentration, not a potency): 81.2%
The estimate for compound 4 lay 19.2 percentage points below the measured number, outside the stated range (above it).
By their numbers in this assay, from the lowest: compound 3; then compounds 1, 4 and 2 (each within the scatter of the next).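

In this assay, methyl in place of hydrogen on this oxygen gives a number 1 percentage points higher from compound 1 to compound 4 (within the scatter), so a free hydroxy here is not needed for the effect at the one concentration tested. This is not the hydroxy missing from compound 3: compound 4 keeps that one and caps the hydroxy compound 3 still carries, so the loss seen with compound 3 does not extend to this position. No available evidence explains this tolerance.

Open, as far as these compounds go, is whether a longer chain on this oxygen, such as ethyl or benzyl, or an amine in its place, would fare the same. Also open, from the compounds shown here alone, is what methyl on the other hydroxy would do.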